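From fluoro to methoxy on one aromatic carbon

A few compounds are considered here, and "the series" means these few. Any claim that something is new, unique, unknown or untested is made for them only; others in the source may bear on it.

- Compound 1 `COc1cc2c(Oc3ccc(NC(=O)Nc4ccccc4)cc3)ccnc2cc1OCCCCCCC(=O)NO` with 1650 nM measured
- Compound 2 `COc1cc2c(Oc3ccc(NC(=O)Nc4ccccc4F)cc3)ccnc2cc1OCCCCCCC(=O)NO` with 870 nM measured

Both numbers come from a functional assay on A549 cells (Homo sapiens) for antiproliferative activity, read by MTT assay (on this read-out higher numbers stand for weaker inhibition and lower numbers for stronger inhibition), and are the only ones so far. For the measured compounds named here, compound 2 stands within the usual scatter of compound 1, its only measured neighbour. Fluoro in place of hydrogen on an aromatic carbon gave a 1.9-fold lower number from compound 1 to compound 2 (0.28 log units; within the scatter) as the single measured step, so the two compounds cannot yet be told apart.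

Compound 3 `COc1ccccc1NC(=O)Nc1ccc(Oc2ccnc3cc(OCCCCCCC(=O)NO)c(OC)cc23)cc1` is still unmeasured. Compared with compound 2 it carries methoxy in place of fluoro on an aromatic carbon, ortho to a large group, a difference counted as methoxy in place of fluoro on an aromatic carbon in full. Going by the values given here, no measured compound carries methoxy, and the one step at this carbon stayed within the scatter. Compound 2 at 870 nM is therefore the anchor, and no step beyond the scatter is expected in this assay in either direction. The estimated step is a 1.1-fold higher number from compound 2 to compound 3 (0.06 log units; within the scatter) in size. For compound 3 the expected value is 1000 nM within a range from 400 nM to 2500 nM as the estimate.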

Compound 3, half-maximal inhibitory concentration: 16200 nM
Compound 3: the middle estimate sits 16-fold (1.21 log units) below what was measured; the measured number lies above the stated range.
By their numbers in this assay, from the lowest: compounds 2 and 1 (each within the scatter of the next); then compound 3.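

In this assay, the aromatic carbon ortho to a large group turns out to be sensitive to what it carries: hydrogen and fluoro there could not be told apart, yet methoxy brings a 19-fold higher number from compound 2 to compound 3 (1.27 log units; beyond the scatter) and, measured against the compound with plain hydrogen, a 9.8-fold higher number from compound 1 to compound 3 (0.99 log units; beyond the scatter). Both steps point the same way, towards weaker inhibition, so the harmless fluoro swap said little about this carbon in general, and replacing one heavy atom with a group of two heavy atoms that counts one hydrogen-bond acceptor is enough to set compound 3 apart from both neighbours. No measurement available here says why this one change costs so much.

Going by these compounds, whether a methyl group, a chlorine atom or a hydroxyl group on this same carbon would behave like fluoro or like methoxy remains open, and with it what separates the tolerated groups from the poorly tolerated one. On these data alone, it is also open whether methoxy on another carbon of this ring would give a similar loss, or whether the effect belongs to this one carbon alone.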